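This account rests on a few compounds, and the source may have more. Where it says the series, first, only, none or still open, it means among the compounds named here.

Series notes. Compound 1 `Cn1cc(C2=C(c3nn(CCCn4cccc4)c4ncccc34)C(=O)N(c3ccccc3)C2=O)c2ccccc21` is measured in a functional assay on KB cells (Homo sapiens) for antiproliferative activity, read by MTT assay, with a stated time of 48 h; a higher number here means a weaker inhibitor, a lower number a stronger inhibitor. In this assay compound 1 gives > 100000 nM, which is a limit of the assay and not a number. Compound 2 `Cn1cc(C2=C(c3nn(CCCCn4ccnc4)c4ncccc34)C(=O)NC2=O)c2ccccc21` gives > 100000 nM in this assay, again a limit rather than a number. Compound 3 `CN1CCN(CCCn2nc(C3=C(c4cn(C)c5ccccc45)C(=O)NC3=O)c3cccnc32)CC1` gives > 100000 nM in this assay, also a limit. Where compound 1 stands relative to the others cannot be read, since all three values shown sit at the limit of > 100000 nM in this assay, at which 3 of the 3 values shown sit. Going by the values given here, the single step between measured compounds, a step that the two limits leave unreadable from compound 2 to compound 3, is therefore of unreadable size.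

Compound 4 `Cn1cc(C2=C(c3nn(CCCN4CCCCC4)c4ncccc34)C(=O)N(c3ccccc3)C2=O)c2ccccc21` is the unmeasured member. It differs from compound 1 in one place: piperidin-1-yl in place of 1H-pyrrol-1-yl on a saturated chain carbon, three bonds along the chain from an aromatic nitrogen. Among the compounds with values here, the one step that bears on swapping a ring on the saturated chain carbon is a step that the two limits leave unreadable from compound 2 to compound 3, and its size is hidden by the two limits. No readable step is available, so no direction can be expected beyond the scatter. Compound 4 is expected to sit at 100000 nM, ranging 30000 nM to 300000 nM, with a further limit the likely report because compound 1 and its two neighbours all rest at the limit of > 100000 nM in this assay, at which 3 of the 3 values shown sit. The expected step of a number no higher from compound 1 to compound 4 (the limit leaves the size open) is thus essentially flat.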

Compound 4, half-maximal inhibitory concentration: 5600 nM
Beside the measured number, compound 4's estimate is 18-fold (1.25 log units) above it, and the stated range ends above it.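

Piperidin-1-yl in place of 1H-pyrrol-1-yl gives an at least 17-fold lower number from compound 1 to compound 4 (1.25 log units; beyond the scatter), the first readable step in the series in this assay. This shows that the ring on this saturated chain carbon can by itself bring a compound off the limit, which the step from compound 2 to compound 3 could not show, since that step cannot be read. Compound 1, compound 2 and compound 3 remain limits of the assay and not numbers: the limit of > 100000 nM in this assay, at which 3 of the 4 values shown sit.

Still open, going by these compounds, is whether the lower number holds for a morpholin-4-yl ring, an open dimethylamino group or a longer chain in place of the 3-(piperidin-1-yl)propyl group. Also open, on these data alone, is whether piperidin-1-yl gives a readable value when the amide hydrogen of compound 2 replaces the phenyl group of compound 4.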